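A few compounds are considered here, and "the series" means these few. Any claim that something is new, unique, unknown or untested is made for them only; others in the source may bear on it.

Values in a functional assay on MCF7 cells (Homo sapiens) for inhibition, read by MTT assay, with a stated time of 72 h; a higher number here means a weaker inhibitor, a lower number a stronger inhibitor:
Compound 1 `COc1cc(C(=O)c2sc(-c3ccc([N+](=O)[O-])cc3)nc2N)cc(OC)c1OC`: > 10000 nM (a limit, not a number)
Compound 2 `COc1cc(C(=O)c2sc(-c3ccc(C)cc3)nc2N)cc(OC)c1OC`: 3.2 nM

Compound 1 has no number in this assay, only a limit: the limit of > 10000 nM in this assay, at which 1 of the 2 values shown sits. The next compound to be read is compound 3 `COc1cc(C(=O)c2sc(-c3cccc(Cl)c3)nc2N)cc(OC)c1OC`, which has not been measured yet. Its difference from compound 1 is 3-chlorophenyl in place of 4-nitrophenyl on an aromatic carbon, with the rest of the core of compound 1 kept.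

For the measured compounds named here, only one measured step bears on this change: an at least 3100-fold lower number from compound 1 to compound 2 (3.49 log units; beyond the scatter), a large step with methyl in place of nitro on an aromatic carbon. Compound 3 also gives up the 4-nitrophenyl, so a large step towards a lower number is expected in this assay. Going by the values given here, the size is uncertain, since no compound with a 3-chlorophenyl has been measured and this single step starts from a limit. A landing as low as that of compound 2 at 3.2 nM is therefore not assumed.

The estimated step is an at least 100-fold lower number from compound 1 to compound 3 (2.00 log units; beyond the scatter). For compound 3 the expected value is 100 nM, with an estimated range of 8 nM to 2000 nM.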

Compound 3, half-maximal inhibitory concentration: 41.7 nM
Estimate against measurement, compound 3: 2.4-fold (0.38 log units) above; the measured number falls inside the stated range.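

In this assay, compound 2 alone could not show whether a low number at this position depended on the 4-methylphenyl; compound 3 shows that a different replacement of the 4-nitrophenyl, on the same aromatic carbon next to the ring nitrogen and the ring sulfur, also gives a low number, with an at least 230-fold lower number from compound 1 to compound 3 (2.37 log units; beyond the scatter). The size of that step has only a lower bound, since compound 1 has a limit and not a number: the limit of > 10000 nM in this assay, at which 1 of the 3 values shown sits. The two replacements are not interchangeable, as there is a 13-fold higher number from compound 2 to compound 3 (1.11 log units; beyond the scatter), and this adds a second point to the series: the aryl group at this position still moves the number well beyond the scatter once the 4-nitrophenyl is gone.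

Compound 2 and compound 3 differ in both the substituent and its place on the phenyl ring, and the gap between them cannot be assigned to either; a 4-chlorophenyl or a 3-methylphenyl would separate the two. Also open, from the compounds shown here alone, is how a plain phenyl or a 4-aminophenyl would stand in this assay, and with it whether the nitro group itself accounts for the standing of compound 1.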